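Swapping a Carbonate Ester for a Plain Isopropyl Ester

The source may hold more compounds than are shown below. What is called first, only, known or untested is meant among the compounds shown, and "the series" means these compounds.

Compound 1 `CC(C)OC(=O)OCOC(=O)C1=C(S[C@@H]2CN[C@H](C(=O)Nc3cccc(C(=O)O)c3)C2)[C@H](C)[C@@H]2[C@@H]([C@@H](C)O)C(=O)N12` carries a ((isopropoxycarbonyl)oxy)methyl group on an oxygen next to a carbonyl group of the shared core. In an ADME assay for metabolic stability, read by LC-MS, with a stated time of 3 h, at pH 6.5, tested at 50 uM (on this read-out lower numbers stand for a less stable compound and higher numbers for a more stable compound), compound 1 gives > 95%, which is a limit of the assay rather than a measured number. Compound 2 `CC(C)OC(=O)OCOC(=O)C1=C(S[C@@H]2CN[C@H](C(=O)Nc3cccc(C(=O)OCOC(=O)OC(C)C)c3)C2)[C@H](C)[C@@H]2[C@@H]([C@@H](C)O)C(=O)N12` adds a second such group on the free acid; in this assay compound 2 gives > 95%, again a limit. Compound 3 `CCC(=O)OCOC(=O)C1=C(S[C@@H]2CN[C@H](C(=O)Nc3cccc(C(=O)OCOC(=O)CC)c3)C2)[C@H](C)[C@@H]2[C@@H]([C@@H](C)O)C(=O)N12` carries propanoyloxymethyl esters at both places, and in this assay compound 3 gives > 95%, also a limit. Among the compounds with values here, the step that the two limits leave unreadable from compound 1 to compound 2 can therefore not be sized, and the limit of > 95% in this assay, at which 3 of the 3 values shown sit, shows that every value so far sits at the same limit, so the measured compounds give no readable size for any change at the ester.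

Compound 4 `CC(C)OC(=O)C1=C(S[C@@H]2CN[C@H](C(=O)Nc3cccc(C(=O)O)c3)C2)[C@H](C)[C@@H]2[C@@H]([C@@H](C)O)C(=O)N12` differs from compound 1 in one place: isopropyl in place of ((isopropoxycarbonyl)oxy)methyl on an oxygen next to a carbonyl group. Within the data shown here, no measured step covers this exchange, and the limit at which compound 1 stands sets only a floor for where compound 4 might land. Compound 4 is expected to remain largely intact, with an estimated 90% in this assay, within a range from 60% to 99%. Among the measured compounds shown here, the expected step of a number at least 5 percentage points lower from compound 1 to compound 4 (that floor lies within the scatter) is an estimate that no measured step supports or contradicts.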

Compound 4, percent of the compound remaining: > 95%
Compound 4: a limit, no number; the forecaster's own chance of this, stated with the estimate: 45%; middle value at least 5 percentage points from the limit.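

In this assay compound 4 gives > 95%, which is a limit of the assay and not a number. Compound 1 also stands at a limit, so the step between compound 1 and compound 4 cannot be read. How much any exchange at the ester changes the percent remaining stays open, because the values offer no measured number to compare: the limit of > 95% in this assay, at which 4 of the 4 values shown sit.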